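A few compounds are considered here, and "the series" means these few. Any claim that something is new, unique, unknown or untested is made for them only; others in the source may bear on it.

Measured compounds:
compound 1 `O=C(Nc1cccc(-n2cc(-c3ccncc3)c(-c3cc(O)cc(Cl)c3)n2)c1)Nc1ccc(Cl)c(Cl)c1` gives -27%
compound 2 `COc1cc(Cl)cc(-c2nn(-c3cccc(NC(=O)Nc4cc(C(F)(F)F)cc(C(F)(F)F)c4)c3)cc2-c2ccncc2)c1` gives -82%

Of the compounds shown here, two have been measured in a functional assay on UO-31 cells (Homo sapiens) for inhibition, read by sulforhodamine B assay, with a stated time of 48 h, tested at 100 uM; a lower number here means a stronger effect, a higher number a weaker effect of the compound at the concentration tested. Compound 1 has the highest of the two numbers, that is the weaker effect; its nearest neighbour is compound 2, which sits a long way lower, beyond the scatter of repeated measurements. Among the measured compounds shown here, no single-point step between measured compounds is available, so the two values show only that compound 2 acts more strongly than compound 1 at the concentration tested.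

Compound 3 `COc1cc(Cl)cc(-c2nn(-c3cccc(NC(=O)Nc4ccc(Cl)c(Cl)c4)c3)cc2-c2ccncc2)c1` has not yet been measured. It differs from compound 1 in one place: methyl in place of hydrogen on an oxygen on an aromatic ring. Compound 2 also carries the methoxy group, but it differs from compound 3 elsewhere as well, so its value cannot be read as the effect of this change alone.

For the measured compounds named here, since no step of this kind has been measured, the author expects a change of modest size, leaning in the direction of a stronger effect, although a result within the scatter of compound 1 would not surprise. For compound 3 the estimate in this assay is -45%, within -85% to -5%, which means an expected step of a number 18 percentage points lower from compound 1 to compound 3 (beyond the scatter).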

Compound 3, a percentage reported as activity, at one concentration (the size of the read-out at that concentration, not a potency): -10%
Estimate against measurement, compound 3: 35 percentage points below; measured number inside the range.
By their numbers in this assay, from the lowest: compound 2; then compound 1; then compound 3.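

Among the compounds shown here, this is the first reading of a single change at this position. In this assay, exchanging hydroxy for methoxy on the 3-chloro-5-hydroxyphenyl group gives a number 17 percentage points higher from compound 1 to compound 3 (beyond the scatter), so the methoxy compound has the weaker effect at the concentration tested, and the addition of one methyl on this oxygen is enough to move the read-out beyond the usual scatter. The substituent on this oxygen therefore matters for the result in these cells, and the free hydroxy of compound 1 goes with the stronger effect in this pair, although nothing shown here gives a reason for the shift.

The compounds shown leave open whether the difference depends on the hydrogen of the hydroxy itself or on the added methyl, which a comparison with an amine or an ethoxy group at the same place could begin to separate. They also leave open whether the same step would appear with the different substituents that compound 2 carries elsewhere, as a single pair cannot establish a wider pattern.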